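This account rests on a few compounds, and the source may have more. Where it says the series, first, only, none or still open, it means among the compounds named here.

Within the data shown here, in a functional assay on MCF-10A cells (Homo sapiens) for antiproliferative activity, with a stated time of 48 h (on this read-out lower numbers stand for an effect already at smaller amounts and higher numbers for an effect only at larger amounts of compound), compound 1 `COc1ccc2nc(C)cc(NCc3ccccc3)c2c1` gives 28600 nM, which places it at the high end of the three numbers so far. Compound 2 `COc1ccc2nc(C)cc(NCc3ccccc3F)c2c1` gives 17000 nM, level with compound 1 within the scatter. Compound 3 `COc1ccc2nc(C)cc(NCc3ccc(C(F)(F)F)cc3)c2c1` gives 7600 nM.

The next compound to be read is compound 4 `COc1ccc2nc(C)cc(NCc3cccc(OC(F)F)c3)c2c1`. It differs from compound 1 by difluoromethoxy in place of hydrogen on an aromatic carbon. Among the measured compounds shown here, no measured compound carries this group, so the closest evidence is the two measured steps that also bring in a group holding fluorine. The fluoro change gives a 1.7-fold lower number from compound 1 to compound 2 (0.23 log units; within the scatter). The trifluoromethyl change gives a 3.8-fold lower number from compound 1 to compound 3 (0.58 log units; beyond the scatter). Both point to a lower number, but only the second clears the scatter, and two steps make a thin basis. A modest step toward a lower number in this assay is therefore expected, of a size between these two, with no change beyond the scatter remaining possible. The expected step is a 2.4-fold lower number from compound 1 to compound 4 (0.38 log units; beyond the scatter). For compound 4 the estimate is 12000 nM, with an expected range from 5000 nM to 26000 nM.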

Compound 4, half-maximal effective concentration: 14300 nM
For compound 4 the middle estimate is 1.2-fold (0.08 log units) below the measured one, within the range that was stated.
By their numbers in this assay, from the lowest: compounds 3, 4, 2 and 1 (each within the scatter of the next, the first and the last beyond it).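

At this place, on an aromatic carbon of a six-membered aromatic ring of carbon only and meta to a large group, difluoromethoxy adds 4 heavy atoms, and this assay shows a 2.0-fold lower number from compound 1 to compound 4 (0.30 log units; within the scatter). This adds a third fluorine-bearing change: the fluoro change gives a 1.7-fold lower number from compound 1 to compound 2 (0.23 log units; within the scatter) and the trifluoromethyl change, the one exception, gives a 3.8-fold lower number from compound 1 to compound 3 (0.58 log units; beyond the scatter), so among the compounds shown a fluorine-bearing group does not by itself take the number beyond the scatter. Nothing measured on these groups accounts for the result.

The compounds shown hold no single group at two different places on this ring, so the effect of the group and the effect of its place cannot yet be separated, and it stays open whether difluoromethoxy elsewhere on the ring would read differently from compound 4. Also open, as far as these compounds go, is how this same place responds to groups of another kind, such as an amine, a carboxylic acid or a plain methoxy, and whether any of them would give a step beyond the scatter in either direction in this assay.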